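Benzyloxy for Allyloxy on a Compound Already Beyond the Limit

The compounds below may be only part of what the source reports. "The series", "measured", "known", "first", "only" and "open" are said of these compounds alone.

Compound 1, `C=CCONC(=O)CN1C(=O)S/C(=C\c2ccc(C(=O)N[C@@H](CC(C)C)C(=O)OC)cc2)C1=O`: in a functional assay on MRC5 cells (Homo sapiens) for inhibition, read by microscopy and resazurin assay, with a stated time of 72 h (a higher number here means a weaker inhibitor, a lower number a stronger inhibitor), compound 1 gives > 128000 nM, a limit of the assay rather than a number.
Compound 2, `COC(=O)[C@H](CC(C)C)NC(=O)c1ccc(/C=C2\SC(=O)N(CC(=O)NOCc3ccccc3)C2=O)cc1`: in this assay compound 2 gives > 128000 nM, again a limit.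
Compound 3, `C=CCONC(=O)CN1C(=O)S/C(=C\c2ccc(C(=O)N[C@H](C(=O)OC)C(C)C)cc2)C1=O`: in this assay compound 3 gives > 128000 nM, also a limit.

Compound 3 therefore stands nowhere readable: all three measured values sit at the limit of > 128000 nM in this assay, at which 3 of the 3 values shown sit, so none of them can be ordered against another. Compound 4, `COC(=O)[C@@H](NC(=O)c1ccc(/C=C2\SC(=O)N(CC(=O)NOCc3ccccc3)C2=O)cc1)C(C)C`, differs from compound 3 by phenyl in place of vinyl on a saturated chain carbon bound to an oxygen on an unsaturated carbon. The same change, measured from compound 1 to compound 2, gave a step that the two limits leave unreadable from compound 1 to compound 2, and the other measured step, a step that the two limits leave unreadable from compound 1 to compound 3, is equally unreadable. No size or direction can be expected from these data, and the estimated step that the limit leaves unreadable from compound 3 to compound 4 most likely ends in another limit. Compound 4 is estimated at 150000 nM, within 40000 nM to 500000 nM.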

Compound 4, half-maximal inhibitory concentration: > 128000 nM
Compound 4 ended at the assay's limit; the forecaster's own chance of this, stated with the estimate: 85%; the middle value is on the limit's open side.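

In this assay compound 4 gives > 128000 nM, again a limit, so its steps from compound 2 and compound 3 cannot be read. The compounds shown leave open where each true value lies, and whether either change, benzyloxy for allyloxy or isopropyl for isobutyl, alters inhibition at all.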